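Removing One Hydroxy Group From A Boron-Containing Chalcone

This account rests on a few compounds, and the source may have more. Where it says the series, first, only, none or still open, it means among the compounds named here.

Compound 3 `O=C(/C=C/c1ccc2c(c1)B(O)OC2)c1ccc(O)c(O)c1` is the starting point. In a toxicity assay on WI-38 cells (Homo sapiens) for cytotoxicity, read by MTT assay, with a stated time of 48 h (on this read-out higher numbers stand for weaker inhibition and lower numbers for stronger inhibition), compound 3 gives > 100000 nM, which is a limit of the assay and not a number. Compound 3 thus sits at the limit of > 100000 nM in this assay, at which 2 of the 3 values shown sit. Compound 4 `O=C(/C=C/c1ccc2c(c1)B(O)OC2)c1cccc(O)c1` differs from it by hydrogen in place of hydroxy on an aromatic carbon. Two measured compounds bear on this change. Compound 1 `O=C(/C=C/c1ccc2c(c1)B(O)OC2)c1cccc(F)c1` gives 26700 nM in this assay. Compound 2 `O=C(/C=C/c1ccc2c(c1)B(O)OC2)c1ccccc1O` gives > 100000 nM, again a limit of the assay. The step of an at least 3.7-fold higher number from compound 1 to compound 2 (0.57 log units; beyond the scatter) shows a hydroxyphenyl partner pushing the number to the limit. Compound 4 keeps a hydroxy group, and the expected step of an at least 1.1-fold lower number from compound 3 to compound 4 (0.07 log units; that floor lies within the scatter) is small, likely within the scatter. The estimate for compound 4 is 85000 nM, in the range 30000 nM to 200000 nM.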

Compound 4, half-maximal inhibitory concentration: 26400 nM
Compound 4: the middle estimate sits 3.2-fold (0.51 log units) above what was measured, and the stated range ends above it.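

In this assay, taking away one hydroxy group gives an at least 3.7-fold lower number from compound 3 to compound 4 (0.57 log units; beyond the scatter), so the hydroxy group ortho to the remaining one matters here. A hydroxy group as such does not hold the number at the limit: with the 3-hydroxyphenyl in place of the 2-hydroxyphenyl there is an at least 3.7-fold lower number from compound 2 to compound 4 (0.57 log units; beyond the scatter). With a 1.0-fold lower number from compound 1 to compound 4 (0.00 log units; within the scatter), hydroxy and fluoro cannot be told apart on this read-out.

On these data alone, the true values of compound 2 and compound 3 stay open, as each is only a limit of the assay: the limit of > 100000 nM in this assay, at which 2 of the 4 values shown sit. As far as these compounds go, how an amine or a carboxylic acid would behave in place of this hydroxy group also remains open.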